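Halogen swap on two hydrazide-type cores against liver cells

The source may report more compounds than this note shows. Statements on the series, on what has been measured and on what is new or still open speak of the compounds shown alone.

Two measured compounds share one core: compound 1 `O=C(N/N=C/c1cc(I)cc(I)c1O)c1ccc(Cl)cc1` and compound 2 `O=C(N/N=C/c1cc(I)cc(I)c1O)c1ccc(Br)cc1`. In a functional assay on HepG2 cells (Homo sapiens) for cytotoxicity, with a stated time of 24 h (a higher number here means a weaker inhibitor, a lower number a stronger inhibitor), compound 1 gives 14800 nM. In this assay compound 2 gives 22300 nM. The change between them is bromo in place of chloro on an aromatic carbon, and it made a 1.5-fold higher number from compound 1 to compound 2 (0.18 log units; within the scatter).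

Compound 3 `O=C(NNC(=O)c1cc(I)cc(I)c1O)c1ccc(Cl)cc1` has a different core; how it differs from the core of compound 1 is not broken down here. In this assay compound 3 gives 48700 nM, the highest of the three numbers. Compound 4 `O=C(NNC(=O)c1cc(I)cc(I)c1O)c1ccc(Br)cc1` is not yet measured and differs from compound 3 by bromo in place of chloro on an aromatic carbon, the same change that turns compound 1 into compound 2, at the same kind of place on the ring.

For compound 4 a step of about a 1.4-fold higher number from compound 3 to compound 4 (0.16 log units; within the scatter) in this assay is expected, because the same change gave a 1.5-fold higher number from compound 1 to compound 2 (0.18 log units; within the scatter), a step that stayed within the scatter. The estimate for compound 4 in this assay is therefore 70000 nM, expected to fall between 32000 nM and 150000 nM, resting on that single earlier step.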

Compound 4, half-maximal inhibitory concentration: 62800 nM
Beside the measured number, compound 4's estimate is 1.1-fold (0.05 log units) above it; measured number inside the range.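

On the core of compound 3, replacing 4-chlorophenyl with 4-bromophenyl gave a 1.3-fold higher number from compound 3 to compound 4 (0.11 log units; within the scatter) in this assay. Set beside the same change on the core of compound 1, the two steps agree: the same change on two cores in this assay, a 1.5-fold higher number (0.18 log units; within the scatter) from compound 1 to compound 2 and a 1.3-fold higher number (0.11 log units; within the scatter) from compound 3 to compound 4, 1.2-fold (0.07 log units) apart, within the scatter of two such steps. Across these two pairs, then, the change carries over from one core to the other as a step too small to tell apart from the ordinary variation between repeated measurements, but this does not show that bromo truly gives a weaker inhibitor than chloro, and two pairs cannot establish a rule for any further core.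

The compounds shown leave open whether a group of a different kind at this place on the ring, such as an amine, a carboxylic acid or a longer chain, would give a step beyond the scatter. They also leave open whether a fluoro group would behave like chloro and bromo on both cores.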